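Notes on the step from compound 3 to compound 4

This account rests on a few compounds, and the source may have more. Where it says the series, first, only, none or still open, it means among the compounds named here.

Three measured compounds share one core and differ only in the aryl group on the amine nitrogen. Compound 1 `Cc1ccc(Nc2ncc(C(F)(F)F)c(N3Cc4cccc(N(C)S(C)(=O)=O)c4C3)n2)c(Cl)c1` carries a 2-chloro-4-methylphenyl there; in an assay on Sf9 cells for inhibition of tyrosine-protein kinase receptor UFO (Homo sapiens), read by luminescence and ADP-Glo (on this read-out lower numbers stand for stronger inhibition and higher numbers for weaker inhibition), compound 1 gives only a limit, > 20000 nM. Compound 2 `CN(c1cccc2c1CN(c1nc(Nc3cc(C(F)(F)F)cc(C(F)(F)F)c3)ncc1C(F)(F)F)C2)S(C)(=O)=O` carries a different aryl group; in this assay compound 2 likewise gives only a limit, > 20000 nM. Compound 3 `CN(c1cccc2c1CN(c1nc(Nc3ccc(Cl)c(C(F)(F)F)c3)ncc1C(F)(F)F)C2)S(C)(=O)=O` carries a 4-chloro-3-(trifluoromethyl)phenyl; in this assay compound 3 also gives only a limit, > 20000 nM. Compound 3 thus stands with the other two at the limit, and the step that the two limits leave unreadable from compound 1 to compound 3 has no readable size because of the limit of > 20000 nM in this assay, at which 3 of the 3 values shown sit.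

Compound 4 `CN(c1cccc2c1CN(c1nc(Nc3cc(Cl)cc(C(F)(F)F)c3)ncc1C(F)(F)F)C2)S(C)(=O)=O` differs from compound 3 by 3-chloro-5-(trifluoromethyl)phenyl in place of 4-chloro-3-(trifluoromethyl)phenyl on a nitrogen on an aromatic ring. Among the measured compounds shown here, no measured step bears on this change with a readable size; every value so far is a limit. The expected step that the limit leaves unreadable from compound 3 to compound 4 is therefore none beyond the scatter. Compound 4 is expected to give about 30000 nM in this assay, with a range from 8000 nM to 100000 nM, most probably reported again as a limit only.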

Compound 4, half-maximal inhibitory concentration: > 30000 nM
Compound 4: no number, only a limit (the forecaster's own chance of this, stated with the estimate: 85%); the middle value lies on the limit itself.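

In this assay compound 4 gives only a limit, > 30000 nM. The steps to compound 4 from compound 1, compound 2 and compound 3 cannot be read: all four values are limits. The compounds shown leave open whether any aryl group on this nitrogen gives a measurable inhibition on the shared core.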